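A few compounds are considered here, and "the series" means these few. Any claim that something is new, unique, unknown or untested is made for them only; others in the source may bear on it.

Measured so far in a functional assay on T47D cells (Homo sapiens) for inhibition, read by sulforhodamine B assay, with a stated time of 48 h, tested at 100 uM; a lower number here means a stronger effect, a higher number a weaker effect of the compound at the concentration tested:

Compound 1, `COc1cc(Cl)cc(-c2nn(-c3cccc(NC(=O)Nc4ccc(Cl)c(C(F)(F)F)c4)c3)cc2-c2ccncc2)c1`: -18%
Compound 2, `COc1cc(Cl)cc(-c2nn(-c3cccc(NC(=O)Nc4cc(C(F)(F)F)cc(C(F)(F)F)c4)c3)cc2-c2ccncc2)c1`: -22%
Compound 3, `COc1cc(Cl)cc(-c2nn(-c3cccc(NC(=O)Nc4ccc(Cl)c(Cl)c4)c3)cc2-c2ccncc2)c1`: -9%

All three share one core and differ only in the aryl group carried on the urea. Compound 3 gives the highest number of the three in this assay; compound 1 stands closest to it and its value lies within the usual scatter of compound 3, whereas compound 2 gives a value that sits beyond the scatter below compound 3. Within the data shown here, the one single-point step available runs a number 9 percentage points higher from compound 1 to compound 3 (within the scatter), and it did not exceed the scatter.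

Compound 4, `COc1cc(Cl)cc(-c2nn(-c3cccc(NC(=O)Nc4cccc(C(F)(F)F)c4)c3)cc2-c2ccncc2)c1`, has not yet been measured. It differs from compound 3 in one place: 3-(trifluoromethyl)phenyl in place of 3,4-dichlorophenyl on an amide-type nitrogen. Among the measured compounds shown here, compound 4 is thus compound 1 with the chloro left out, and the only step that bears on it, a number 9 percentage points higher from compound 1 to compound 3 (within the scatter), was small. No change beyond the scatter is therefore expected in this assay for compound 4. Compound 4 is expected to give about -14%, within a range from -30% to 2%, which means an expected step of a number 5 percentage points lower from compound 3 to compound 4 (within the scatter).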

Compound 4, a percentage reported as activity, at one concentration (the size of the read-out at that concentration, not a potency): -25%
Compound 4: the middle estimate sits 11 percentage points above what was measured; the measured number falls inside the stated range.
By their numbers in this assay, from the lowest: compounds 4, 2, 1 and 3 (each within the scatter of the next, the first and the last beyond it).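

Among these compounds, putting 3-(trifluoromethyl)phenyl in place of 3,4-dichlorophenyl on the amide-type nitrogen gave the only single-place step in this assay that passes the scatter (a number 16 percentage points lower from compound 3 to compound 4 (beyond the scatter)). The other two steps stayed within it, with hydrogen in place of chloro (a number 7 percentage points lower from compound 1 to compound 4 (within the scatter)) and hydrogen in place of trifluoromethyl (a number 3 percentage points lower from compound 2 to compound 4 (within the scatter)), so removing one group does not separate compound 4 from compound 1 or compound 2, and the gap appears only against the 3,4-dichlorophenyl of compound 3. No measurement at hand offers an explanation for this gap.

Still open, as far as these compounds go, is how an aryl group carrying a nitrile or a carboxylic acid would read at this place, and whether a longer alkyl chain could stand in for the aromatic ring on that nitrogen. Each value also stands for one concentration and gives no potency.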